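Working notes: removing one fluoro from compound 2

The compounds below may be only part of what the source reports. "The series", "measured", "known", "first", "only" and "open" are said of these compounds alone.

Measured compounds:
Compound 1, `COC(=O)c1ccc(CN(CCCc2c(N)nc(N)nc2O)c2cc(F)cc(F)c2[N+](=O)[O-])cc1`. In a functional assay on CCRF-CEM cells (Homo sapiens) for cytotoxicity, in the absence of a further agent (on this read-out higher numbers stand for weaker inhibition and lower numbers for stronger inhibition), compound 1 gives > 100000 nM, which is a limit of the assay and not a number.
Compound 2, `Nc1nc(N)c(CCCN(Cc2ccc(NC(CCC(=O)O)C(=O)O)cc2)c2cc(F)cc(F)c2[N+](=O)[O-])c(O)n1`. In this assay compound 2 gives > 100000 nM, again a limit of the assay.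
Compound 3, `CC(C)(C)OC(=O)CCC(Nc1ccc(CN(CCCc2c(N)nc(N)nc2O)c2cc(F)cc(F)c2[N+](=O)[O-])cc1)C(=O)OC(C)(C)C`. In this assay compound 3 gives 2400 nM.

Compound 2 therefore stands at the limit, where two of the three values sit (the limit of > 100000 nM in this assay, at which 2 of the 3 values shown sit). The step that the two limits leave unreadable from compound 1 to compound 2 is unreadable for the same reason. Within the data shown here, compound 3 is the only compound with a number.

Compound 4, `Nc1nc(N)c(CCCN(Cc2ccc(NC(CCC(=O)O)C(=O)O)cc2)c2cc(F)ccc2[N+](=O)[O-])c(O)n1`, differs from compound 2 by hydrogen in place of fluoro on an aromatic carbon. Among the measured compounds shown here, no measured step changes a fluoro on this ring, so nothing measured bears directly on this change; the only readable comparison, compound 3 against compound 2, concerns the ester and not the ring. Compound 4 is therefore expected to stay close to where compound 2 stands, with the step of a number no higher from compound 2 to compound 4 (the limit leaves the size open) expected to be within the scatter and most likely to leave only a limit again. The estimate for compound 4 in this assay is 100000 nM, with a range from 20000 nM to 500000 nM.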

Compound 4, half-maximal inhibitory concentration: > 100000 nM
Compound 4 ended at the assay's limit; the forecaster's own chance of this, stated with the estimate: 70%; the middle value lies on the limit itself.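

Compound 2 and compound 4 both stand at a limit of the assay and not at a number, so no step between them can be read: the limit of > 100000 nM in this assay, at which 3 of the 4 values shown sit.

Going by these compounds, whether the change from 3,5-difluoro-2-nitrophenyl to 5-fluoro-2-nitrophenyl alters the inhibition at all stays open.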